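A few compounds are considered here, and "the series" means these few. Any claim that something is new, unique, unknown or untested is made for them only; others in the source may bear on it.

Going by the values given here, compound 2 `CN1CCN(c2ccc(C3=NN(S(=O)(=O)c4ccc(C(F)(F)F)cc4)C(c4ccc(N(C)C)cc4)C3)cc2)CC1` gives 18.9% in a functional assay on NCI-H1975 cells (Homo sapiens) for inhibition, read by sulforhodamine B assay, tested at 10 uM (on this read-out lower numbers stand for less inhibition and higher numbers for more inhibition at the one concentration tested (going by the name of the read-out)), the higher of the two numbers measured so far; compound 1 `CN1CCN(c2ccc(C3=NN(S(C)(=O)=O)C(c4ccc(N(C)C)cc4)C3)cc2)CC1` gives -1.3%. Among the compounds with values here, the only measured step, a number 20.2 percentage points higher from compound 1 to compound 2 (beyond the scatter), exchanged the whole group on the sulfonyl sulfur for a 4-(trifluoromethyl)phenyl. Compound 3 `CN1CCN(c2ccc(C3=NN(S(=O)(=O)c4ccc(OC(F)(F)F)cc4)C(c4ccc(N(C)C)cc4)C3)cc2)CC1` differs from compound 2 by trifluoromethoxy in place of trifluoromethyl on an aromatic carbon. Within the data shown here, this change sits inside the aromatic ring that the single measured step brought in, but no measured pair alters a substituent on that ring, so that step bears on the present one only loosely: it shows that the ring as a whole mattered, not what a change at its far end does. With nothing closer to lean on, the expected step of a number 0.9 percentage points lower from compound 2 to compound 3 (within the scatter) is small, lying within the scatter in either direction. Compound 3 is therefore estimated at 18%, with a range from 4% to 32%.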

Compound 3, a percentage reported as inhibition, at one concentration (the size of the read-out at that concentration, not a potency): 26.5%
Beside the measured number, compound 3's estimate is 8.5 percentage points below it; the range from low to high includes it.
By their numbers in this assay, from the lowest: compound 1; then compounds 2 and 3 (each within the scatter of the next).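

In this assay, trifluoromethoxy in place of trifluoromethyl on the aromatic ring gives a number 7.6 percentage points higher from compound 2 to compound 3 (within the scatter), so this first change at the far end of the ring does not separate the two compounds. The step from the methyl on the sulfonyl sulfur, a number 27.8 percentage points higher from compound 1 to compound 3 (beyond the scatter), shows that a second substituted phenyl also stands clear of methyl, so the earlier step from compound 1 to compound 2 is no longer a lone case. Nothing available explains these numbers.

From the compounds shown here alone, whether a group of a different kind at this place on the ring, such as an amine or a carboxylic acid, would move the number beyond the scatter remains open. So does how a plain phenyl with no substituent on the sulfonyl sulfur would compare with compound 2 and compound 3.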